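Fluoromethyl to piperidinylmethyl on the shared core

The source may report more compounds than this note shows. Statements on the series, on what has been measured and on what is new or still open speak of the compounds shown alone.

Compound 1 `Fc1ccc(-c2ccc(-c3cn([C@H]4CN5CCC4CC5)nn3)s2)cn1` gives 440 nM in an assay on isolated protein for displacement of a labelled ligand from 5-hydroxytryptamine receptor 3A (Homo sapiens), read by radioligand binding; a lower number here means a stronger inhibitor, a higher number a weaker inhibitor. Compound 2 `FCc1ccc(-c2ccc(-c3cn([C@H]4CN5CCC4CC5)nn3)s2)cc1` reaches only the limit of > 1000 nM in this assay, a limit rather than a number; this is the limit of > 1000 nM in this assay, at which 1 of the 2 values shown sits. Within the data shown here, the one measured step, an at least 2.2-fold higher number from compound 1 to compound 2 (0.35 log units; beyond the scatter), places compound 2 at the weak end of the two values. Compound 3 `c1cc(-c2ccc(-c3cn([C@H]4CN5CCC4CC5)nn3)s2)ccc1CN1CCCCC1` differs from compound 2 by piperidin-1-yl in place of fluoro on a saturated chain carbon bound to an aromatic carbon. Among the measured compounds shown here, no measured step touches this change, so the expected step is a step that the limit leaves unreadable from compound 2 to compound 3, with wide uncertainty. Compound 3 is therefore estimated at 1500 nM, between 300 nM and 10000 nM.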

Compound 3, inhibition constant: 560 nM
Estimate against measurement, compound 3: 2.7-fold (0.43 log units) above; low and high end bracket the measured number.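

Replacing fluoro with piperidin-1-yl on the saturated chain carbon bound to an aromatic carbon gives, in this assay, an at least 1.7-fold lower number from compound 2 to compound 3 (0.25 log units; that floor lies within the scatter). The position therefore accepts this ring without any loss in binding, but the size of the gain stays unsettled. Compound 2 carries a limit of the assay and not a number: the limit of > 1000 nM in this assay, at which 1 of the 3 values shown sits.

On these data alone, the true gap between the fluoromethyl and piperidinylmethyl groups remains open. So does whether morpholin-4-yl, dimethylamino or a carboxylic acid on that chain carbon would behave like piperidin-1-yl.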